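A few compounds are considered here, and "the series" means these few. Any claim that something is new, unique, unknown or untested is made for them only; others in the source may bear on it.

Measured so far:
Compound 1 `Cc1cc(-c2ccnc3[nH]ncc23)cnc1OCC12CCC(O)(CC1)CC2` — < 1 nM
Compound 2 `Cn1nc(-c2ccc(OCC34CCC(O)(CC3)CC4)c(F)c2)c2cnc(N)nc21` — 75 nM
Compound 3 `Cn1ncc2c(-c3ccc(OCC45CCC(N)(CC4)CC5)c(F)c3)nc(N)nc21` — 18 nM

Of the compounds shown here, three have been tested in an assay on THP-1 cells for antagonist activity at Toll-like receptor 8 (Homo sapiens); on this read-out lower numbers stand for stronger inhibition and higher numbers for weaker inhibition. For compound 1 the result is only a limit of the assay, < 1 nM, not a number (the limit of < 1 nM in this assay, at which 1 of the 3 values shown sits). Among the compounds with values here, compound 2 gives 75 nM, the higher of the two numbers known. Within the data shown here, compound 3 gives 18 nM, a gap beyond the scatter, but it differs from compound 2 in more than one place, so no single step connects them.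

Compound 4 `Cn1nc(-c2ccc(OCCCC3CCNCC3)c(F)c2)c2cnc(N)nc21` differs from compound 2 in one place: a group of 8 heavy atoms (7 carbon, 1 nitrogen; one six-membered non-aromatic ring with 1 hetero atom) in place of a group of 9 heavy atoms (8 carbon, 1 oxygen; 2 six-membered non-aromatic rings of carbon only), on a saturated chain carbon bound to an oxygen on an aromatic ring. Among the measured compounds shown here, no measured step matches this change, so the expectation rests only on the values shown. A modest step toward a lower number is expected, a 1.9-fold lower number from compound 2 to compound 4 (0.27 log units; within the scatter). Compound 4 is therefore estimated at 40 nM, with a range from 10 nM to 160 nM.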

Compound 4, half-maximal inhibitory concentration: 26 nM
Beside the measured number, compound 4's estimate is 1.5-fold (0.19 log units) above it; the range from low to high includes it.
By their numbers in this assay, from the lowest: compounds 3 and 4 (each within the scatter of the next); then compound 2. At a limit, below all of these: compound 1.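

At this place, on a saturated chain carbon bound to an oxygen on an aromatic ring, swapping the two-ring carbon group that carries an oxygen for 2-(piperidin-4-yl)ethyl gives, in this assay, a 2.9-fold lower number from compound 2 to compound 4 (0.46 log units; beyond the scatter). Within the data shown here, this is the first single change that can be read on a shared core, and it shows that the two-ring group is not needed for a low number. Nothing shown bears on why the number moves. This step changes the ring nitrogen and the second ring together, and the compounds shown do not separate them. They also leave open how a longer chain or a morpholine ring at this place would read.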